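This account rests on a few compounds, and the source may have more. Where it says the series, first, only, none or still open, it means among the compounds named here.

Measured in a functional assay on MCF7 cells (Homo sapiens) for antiproliferative activity, read by MTT assay, with a stated time of 48 h; on this read-out lower numbers stand for stronger inhibition and higher numbers for weaker inhibition:

Compound 1 `C=C(c1ccc(OC)cc1NC(=O)CNC)c1ccc(OC)c2c1OC(C)(C)C=C2` gives 400 nM
Compound 2 `C=C(c1ccc(OC)cc1NC(=O)CNCC)c1ccc(OC)c2c1OC(C)(C)C=C2` gives 2100 nM

Compound 2 holds the higher of the two numbers at 2100 nM. Within the data shown here, the one measured step, a 5.3-fold higher number from compound 1 to compound 2 (0.72 log units; beyond the scatter), lies beyond the scatter. The next compound, compound 3 `C=C(c1ccc(OC)cc1NC(=O)CN(C)C)c1ccc(OC)c2c1OC(C)(C)C=C2`, differs from compound 2 by dimethylamino in place of ethylamino on a saturated chain carbon bound to a carbonyl carbon. This puts dimethylamino in place of ethylamino on a saturated chain carbon bound to a carbonyl carbon, with the same atoms joined differently. Among the measured compounds shown here, no measured step makes this exact change, so the evidence is indirect. The nearest guide is a 5.3-fold higher number from compound 1 to compound 2 (0.72 log units; beyond the scatter), which produced the ethylamino group that compound 3 lacks. A partial return towards the number of compound 1 is therefore expected, and the estimated change is a 2.3-fold lower number from compound 2 to compound 3 (0.37 log units; beyond the scatter). For compound 3 the expected value is 900 nM, with an estimated range of 300 nM to 2700 nM.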

Compound 3, half-maximal inhibitory concentration: 500 nM
The estimate for compound 3 lay 1.8-fold (0.26 log units) above the measured number; the range from low to high includes it.
By their numbers in this assay, from the lowest: compounds 1 and 3 (each within the scatter of the next); then compound 2.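

In this assay, the same atoms joined differently on a saturated chain carbon bound to a carbonyl carbon do not give the same result: dimethylamino in place of ethylamino gives a 4.2-fold lower number from compound 2 to compound 3 (0.62 log units; beyond the scatter), so the heavy-atom count of the group does not by itself set the number. Of the two ways shown of adding one carbon to the amine, methyl on the amine nitrogen gives a 1.3-fold higher number from compound 1 to compound 3 (0.10 log units; within the scatter), while methyl on the saturated chain carbon bound to the amine nitrogen gives a 5.3-fold higher number from compound 1 to compound 2 (0.72 log units; beyond the scatter), so only the second moves the number beyond the scatter. Nothing measured here explains this difference.

From the compounds shown here alone, whether diethylamino, or a ring amine such as pyrrolidine or morpholine, would follow dimethylamino or ethylamino remains open. The unsubstituted primary amine would show how the series behaves without any carbon on that nitrogen.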